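The source may report more compounds than this note shows. Statements on the series, on what has been measured and on what is new or still open speak of the compounds shown alone.

Working notes on the series.

Compound 1 `CC(C)=CC[C@@H](OC[C@H](C)O)C1=CC(=O)c2c(O)ccc(O)c2C1=O` carries a 2-hydroxypropyl group on the oxygen on the saturated carbon of the side chain. For the measured compounds named here, in a functional assay on HeLa cells (Homo sapiens) for cytotoxicity, read by MTT assay (a lower number here means a stronger inhibitor, a higher number a weaker inhibitor), compound 1 gives 40300 nM, the lowest of the two numbers so far; its only neighbour, compound 2 `CC(C)=CC[C@@H](OC(=O)CCO)C1=CC(=O)c2c(O)ccc(O)c2C1=O`, gives 67600 nM in this assay, and the two lie within the scatter of each other.

Compound 3 `CC(C)=CC[C@@H](OC(=O)C1CCCOC1)C1=CC(=O)c2c(O)ccc(O)c2C1=O` has not been measured. It differs from compound 1 in one place: (oxan-3-yl)carbonyl in place of 2-hydroxypropyl on an oxygen on a saturated carbon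

Going by the values given here, the one measured step that bears on this change is the replacement of the same 2-hydroxypropyl by a carbonyl-linked group, which gave a 1.7-fold higher number from compound 1 to compound 2 (0.22 log units; within the scatter). Both compound 2 and compound 3 carry a carbonyl on that oxygen, so that step is the closest guide; it lay within the scatter. Among the compounds with values here, the ring of the entering group has no counterpart among the measured compounds, so no step speaks to it. The expectation for this assay is therefore a step of about a 1.3-fold higher number from compound 1 to compound 3 (0.11 log units; within the scatter), no larger than the scatter.

Compound 3 is accordingly estimated at 52000 nM in this assay, with a range from 20000 nM to 130000 nM.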

Compound 3, half-maximal inhibitory concentration: 60500 nM
Beside the measured number, compound 3's estimate is 1.2-fold (0.07 log units) below it; low and high end bracket the measured number.
By their numbers in this assay, from the lowest: compounds 1, 3 and 2 (each within the scatter of the next).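

For the compounds shown here, the change from an ether-linked 2-hydroxypropyl to the larger (oxan-3-yl)carbonyl, which brings in a six-membered non-aromatic ring and removes the hydrogen-bond donor of the leaving group, gives only a small step in this assay (a 1.5-fold higher number from compound 1 to compound 3 (0.18 log units; within the scatter)), so the earlier compounds' flat reading at this oxygen on a saturated carbon now extends to a ring-bearing group. Going by these compounds alone, with the carbonyl link held constant, oxan-3-yl in place of 2-hydroxyethyl on the carbonyl carbon also stays within the scatter (a 1.1-fold lower number from compound 2 to compound 3 (0.05 log units; within the scatter)), which gives the first direct comparison of a ring with an open chain at this position and shows no readable difference between them, while all three compounds remain within the scatter of one another. No supporting evidence is available to explain this flat result.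

The compounds shown leave open whether the ring oxygen of the oxan-3-yl group contributes anything, which a cyclohexyl group on the same carbonyl would test. They also leave open whether an amine, a carboxylic acid or a longer chain at this oxygen would move the number in this assay beyond the scatter.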